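The source may hold more compounds than are shown below. What is called first, only, known or untested is meant among the compounds shown, and "the series" means these compounds.

Measured in an ADME assay on MT4 cells (Homo sapiens) for cytotoxicity, read by MTT assay, with a stated time of 3 days (a higher number here means that more compound is tolerated, a lower number that less compound is tolerated), where a sign marks a limit of the assay and not a number:
compound 1 `CCC(C)(C)NC(=O)COC(=O)c1ccc([N+](=O)[O-])o1` gives > 100000 nM
compound 2 `CC(C)(NC(=O)COC(=O)c1ccc([N+](=O)[O-])o1)c1ccccc1` gives > 100000 nM
compound 3 `CC(C)(C)N(CCC(=O)c1ccccc1)C(=O)COC(=O)c1ccc([N+](=O)[O-])o1` gives "not active" (no number reported)

Compound 3 has no single number, and the other two entries offer only (the limit of > 100000 nM in this assay, at which 2 of the 3 values shown sit). Compound 4 `CC(C)(C)N(Cc1cccc(C(F)(F)F)c1)C(=O)COC(=O)c1ccc([N+](=O)[O-])o1` differs from it as follows: 3-(trifluoromethyl)phenyl in place of benzoylmethyl on a saturated chain carbon bound to an amide-type nitrogen. For the measured compounds named here, the one measured step, a step that the two limits leave unreadable from compound 1 to compound 2, lies at another place in the structure and has no readable size. Going by the values given here, it therefore gives no size to carry over, and no step of definite size or direction is expected in this assay. The value for compound 4 is expected to lie close to the limit, and it is estimated at 70000 nM, within a range of 20000 nM to 100000 nM.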

Compound 4, half-maximal cytotoxic concentration: > 100000 nM
Compound 4: no number, only a limit; the forecaster's own chance of this, stated with the estimate: 55%; middle value at least 1.4-fold (0.15 log units) away from the limit.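

No step can be read from compound 3 to compound 4: compound 4 stands only at a limit of the assay, and compound 3 has no number. The compounds shown leave open whether any of them has a readable half-maximal cytotoxic concentration.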